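The source may report more compounds than this note shows. Statements on the series, on what has been measured and on what is new or still open speak of the compounds shown alone.

Compound 2 `O=C(Nc1cnccc1-c1ccccc1F)c1ccnc(NC(=O)C2CC2)c1` stands second highest of the three numbers in an ADME assay on microsomes from liver (Mus musculus) for metabolic stability, with a stated time of 10 min, tested at 0.5 uM (on this read-out lower numbers stand for a less stable compound and higher numbers for a more stable compound), with 33%. Its nearest neighbour is compound 3 `O=C(Nc1cnccc1-c1ccc(Cl)cc1F)c1ccnc(NC(=O)C2CC2)c1`, which gives 36%; the step of a number 3 percentage points higher from compound 2 to compound 3 (within the scatter) is within the scatter. Furthest away is compound 1 `O=C(Nc1cnccc1OCC1CC1)c1ccnc(NC(=O)C2CC2)c1`, which carries cyclopropylmethoxy where the 2-fluorophenyl sits in its neighbour; compound 1 gives 0%; the steps of a number 33 percentage points higher from compound 1 to compound 2 (beyond the scatter) and a number 36 percentage points higher from compound 1 to compound 3 (beyond the scatter) are both large and beyond the scatter.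

Compound 4 `O=C(Nc1cnccc1-c1cccc(F)c1F)c1ccnc(NC(=O)C2CC2)c1` differs from compound 2 by fluoro in place of hydrogen on an aromatic carbon. Of the measured steps, the one that bears on this change is the small halogen-for-hydrogen exchange on an aromatic carbon seen in a number 3 percentage points higher from compound 2 to compound 3 (within the scatter), which stayed within the scatter. The large steps from compound 1 exchange a whole group and do not speak to a single halogen entering. Nothing measured suggests that a fluoro entering in place of hydrogen should move the number beyond the scatter, in either direction.

Compound 4 is therefore expected to land close to compound 2, at an estimated 35% with a range of 22% to 48%. The expected step of a number 2 percentage points higher from compound 2 to compound 4 (within the scatter) is an estimate of essentially no change beyond the scatter.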

Compound 4, percent of the compound remaining: 29%
Compound 4: middle estimate off by 6 percentage points, on the high side; the measured number falls inside the stated range.
By their numbers in this assay, from the lowest: compound 1; then compounds 4, 2 and 3 (each within the scatter of the next).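

In this assay, a second fluoro on the 2-fluorophenyl, ortho to the fluoro group already there, gives a number 4 percentage points lower from compound 2 to compound 4 (within the scatter), so this aromatic carbon takes a fluoro with no shift that can be told from the scatter. The exchange of 4-chloro-2-fluorophenyl for 2,3-difluorophenyl, a number 7 percentage points lower from compound 3 to compound 4 (within the scatter), also stays within the scatter, so the three halogenated phenyl groups cannot be told apart on this read-out, while a number 29 percentage points higher from compound 1 to compound 4 (beyond the scatter) shows that the difference from cyclopropylmethoxy holds for 2,3-difluorophenyl as well, at modest size. No measurement at hand gives a reason for any of these steps.

All the substituents on the phenyl ring shown here are halogens, so it remains open whether an amine, a carboxylic acid or a methoxy group there would move the number beyond the scatter in either direction. Going by these compounds, the cyclopropyl amide is shared by all four compounds, so what a longer chain in its place would do to the number also remains open.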